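A Fluorine Added to the Sulfonyl-Bearing Phenyl Ring

A few compounds are considered here, and "the series" means these few. Any claim that something is new, unique, unknown or untested is made for them only; others in the source may bear on it.

Three compounds have been measured in a functional assay on PC-3 cells (Homo sapiens) for cytotoxicity, read by MTT assay, with a stated time of 72 h; a lower number here means a stronger inhibitor, a higher number a weaker inhibitor:
Compound 1 `O=S(=O)(c1ccccc1)c1nc2ccccc2nc1N1CCCC1` gives 20800 nM.
Compound 2 `O=S(=O)(c1ccccc1)c1nc2ccccc2nc1N1CCc2ccccc2C1` gives 5010 nM.
Compound 3 `O=S(=O)(c1ccccc1)c1nc2ccccc2nc1N1CCCC(O)C1` gives 2100 nM.

All three share one core and differ only in the ring attached to it by nitrogen. Compound 3 shows the lowest number of the three, and its nearest neighbour is compound 2, whose number is higher by an amount beyond the scatter. For the measured compounds named here, the one step measured so far is a 9.9-fold lower number from compound 1 to compound 3 (1.00 log units; beyond the scatter), and it changes the nitrogen-linked ring, not the phenyl ring that carries the sulfonyl group.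

Compound 4 `O=S(=O)(c1ccc(F)cc1)c1nc2ccccc2nc1N1CCCC(O)C1` keeps the 3-hydroxypiperidin-1-yl group of compound 3 and changes the other side: fluoro in place of hydrogen on an aromatic carbon. Read one bond further out, the change is phenyl to 4-fluorophenyl. Going by the values given here, none of the measured steps touches this ring, so there is no measured precedent for the change. A single fluorine in place of a hydrogen is a small alteration, and without a guiding step the expectation is a number close to that of compound 3, with a 1.1-fold lower number from compound 3 to compound 4 (0.02 log units; within the scatter) expected to stay within the scatter. For compound 4 the estimate in this assay is 2000 nM, with a range from 700 nM to 6000 nM.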

Compound 4, half-maximal inhibitory concentration: 2130 nM
Compound 4: the middle estimate sits 1.1-fold (0.03 log units) below what was measured, and the stated range covers the measured number.
By their numbers in this assay, from the lowest: compounds 3 and 4 (each within the scatter of the next); then compound 2; then compound 1.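

In this assay the first measured structural difference on the phenyl ring that carries the sulfonyl group gives a 1.0-fold higher number from compound 3 to compound 4 (0.01 log units; within the scatter) and so lies within the scatter: with the 3-hydroxypiperidin-1-yl group held fixed, compound 3 and compound 4 cannot be told apart. Fluoro in place of hydrogen at this place, para to a large group, therefore has no measurable effect on the number in this one pair, whereas the nitrogen-linked ring gave a 9.9-fold lower number from compound 1 to compound 3 (1.00 log units; beyond the scatter) and so lay beyond the scatter. The compounds shown contain nothing that explains why the hydrogen and the fluoro compounds read alike.

A single fluorine is only one small substituent at one place, so this pair does not show whether the phenyl ring would respond to something larger, such as a methoxy group, an amine or a carboxylic acid, or to a fluorine elsewhere on the ring. It also leaves open whether the same fluorine would read the same way alongside the pyrrolidin-1-yl ring of compound 1 or the nitrogen-linked ring of compound 2.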